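The source may hold more compounds than are shown below. What is called first, only, known or untested is meant among the compounds shown, and "the series" means these compounds.

Compound 1, `CCOc1cccc2cc(-c3ccc(OC)cc3)c(=O)oc12`, gives 5320 nM in an assay on CHO cells for displacement of a labelled ligand from adenosine receptor A3 (Homo sapiens), read by radioligand binding; a higher number here means a weaker inhibitor, a lower number a stronger inhibitor.
Compound 2, `CCOc1cccc2cc(-c3ccc([N+](=O)[O-])cc3)c(=O)oc12`, gives > 100000 nM in this assay, which is a limit of the assay and not a number.

Compound 1 thus stands as the only number shown. Compound 3, `COc1ccc(-c2cc3cccc(OC)c3oc2=O)cc1`, differs from it by hydrogen in place of methyl on a saturated chain carbon bound to an oxygen on an aromatic ring. For the measured compounds named here, the one measured step, an at least 18-fold higher number from compound 1 to compound 2 (1.27 log units; beyond the scatter), changes a different group and so does not bear on this change; no measured step touches the ethoxy. With nothing pointing either way, the step from compound 1 to compound 3 is expected to stay within the scatter, a 1.1-fold lower number from compound 1 to compound 3 (0.03 log units; within the scatter). Compound 3 is therefore estimated at 5000 nM, with a range from 1500 nM to 16000 nM.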

Compound 3, inhibition constant: 5060 nM
For compound 3 the middle estimate is 1.0-fold (0.01 log units) below the measured one; the range from low to high includes it.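

In this assay, ethoxy and methoxy on the shared core cannot be told apart: the step is a 1.1-fold lower number from compound 1 to compound 3 (0.02 log units; within the scatter). For the compounds shown here, this is the first measured change at this place, and losing the one methyl carbon leaves the value within the scatter. Nothing measured here offers a reason for this result.

The compounds shown leave open whether a longer chain such as propoxy, or a hydroxyl or an amine in this place, would keep the value. They also leave open whether methoxy and ethoxy would match on a core carrying a different aromatic group.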